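Aryl exchange on the sulfonyl sulfur: compound 3

The source may hold more compounds than are shown below. What is called first, only, known or untested is meant among the compounds shown, and "the series" means these compounds.

In an ADME assay on cells (Hepatocyte, Mus musculus) for cytotoxicity, read by MTT assay, with a stated time of 24 h (a higher number here means that more compound is tolerated, a lower number that less compound is tolerated), compound 1 (`COc1ccc(S(=O)(=O)n2c(-c3cn(-c4ccccc4)nc3-c3ccc(C(F)(F)F)cc3)nc3ccccc32)cc1`) gives 87400 nM and compound 2 (`Cc1ccc(C)c(S(=O)(=O)n2c(-c3cn(-c4ccccc4)nc3-c3ccc(C(F)(F)F)cc3)nc3ccccc32)c1`) gives 132000 nM, so compound 2 stands level with compound 1 within the scatter. Compound 3 (`O=[N+]([O-])c1ccc(S(=O)(=O)n2c(-c3cn(-c4ccccc4)nc3-c3ccc(C(F)(F)F)cc3)nc3ccccc32)cc1`) has 4-nitrophenyl in place of 2,5-dimethylphenyl on a sulfonyl sulfur. Within the data shown here, the one measured step bearing on this is a 1.5-fold higher number from compound 1 to compound 2 (0.18 log units; within the scatter), also an exchange on the sulfonyl sulfur. Among the measured compounds shown here, no compound with 4-nitrophenyl has been measured yet. The expected step is a 1.3-fold lower number from compound 2 to compound 3 (0.12 log units; within the scatter), which stays within the scatter. For compound 3 the estimated value is 100000 nM, with an expected range of 45000 nM to 220000 nM.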

Compound 3, half-maximal cytotoxic concentration: 178000 nM
For compound 3 the middle estimate is 1.8-fold (0.25 log units) below the measured one, within the range that was stated.
By their numbers in this assay, from the lowest: compounds 1, 2 and 3 (each within the scatter of the next, the first and the last beyond it).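

In this assay, 4-nitrophenyl and 2,5-dimethylphenyl on the sulfonyl sulfur cannot be told apart, with a 1.3-fold higher number from compound 2 to compound 3 (0.13 log units; within the scatter) as the step. Nitro in place of methoxy on an aromatic carbon gives the first step in the series to pass the scatter, though only modestly, with a 2.0-fold higher number from compound 1 to compound 3 (0.31 log units; beyond the scatter) as the step. Nothing measured here accounts for that step.

Still open, on these data alone, is whether an amine or a carboxylic acid in place of nitro would fall in the same range. As far as these compounds go, the effect of an alkyl chain in place of the aryl group on the sulfonyl sulfur also remains open.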